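The compounds below may be only part of what the source reports. "The series", "measured", "known", "first", "only" and "open" are said of these compounds alone.

Measured in a toxicity assay on MT2 cells (Homo sapiens) for cytotoxicity, read by XTT assay, with a stated time of 4 days; a higher number here means that more compound is tolerated, a lower number that less compound is tolerated:
- Compound 1 `Cc1nc(C)c([C@H](OC(C)(C)C)C(=O)O)c(N2CCC(C)(C)CC2)c1-c1ccc(SCCc2ccc(F)cc2)cc1`: >= 32000 nM
- Compound 2 `Cc1nc(C)c([C@H](OC(C)(C)C)C(=O)O)c(N2CCC(C)(C)CC2)c1-c1ccc(OCCc2ccccn2)cc1`: >= 25000 nM

Both entries are limits of the assay, not numbers. Compound 2 therefore has no exact place in this assay. It is known only through its limit of >= 25000 nM. Compound 1 likewise stands at its limit of >= 32000 nM.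

Compound 3 `Cc1ncsc1CCOc1ccc(-c2c(C)nc(C)c([C@H](OC(C)(C)C)C(=O)O)c2N2CCC(C)(C)CC2)cc1` keeps the shared core and the ethoxy link of compound 2 and changes only the terminal ring: 4-methyl-1,3-thiazol-5-yl in place of pyridin-2-yl on a saturated chain carbon, two bonds along the chain from an oxygen on an aromatic ring. In words, 4-methyl-1,3-thiazol-5-yl takes the place of pyridin-2-yl.

Among the measured compounds shown here, only one measured step bears on this change: a step that the two limits leave unreadable from compound 1 to compound 2. It alters the same substituent on the aromatic ring, but it offers no size to carry over. With no readable step as a guide, no shift beyond the scatter is expected in this assay, in either direction. The expected step is a number no higher from compound 2 to compound 3 (the limit leaves the size open). Compound 3 may well also be reported only as a limit. The estimated value for compound 3 is 25000 nM, with an expected range from 10000 nM to 50000 nM.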

Compound 3, half-maximal cytotoxic concentration: >= 25000 nM
Compound 3 gave a limit, no number; the forecaster's own chance of this, stated with the estimate: 65%; the middle value lies on the limit itself.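

In this assay compound 3 gives >= 25000 nM, a limit and not a number. No step among compound 1, compound 2 and compound 3 can be read, since all three are known only through limits: the limit of >= 25000 nM in this assay, at which 2 of the 3 values shown sit.

The compounds shown leave open whether 4-methyl-1,3-thiazol-5-yl and pyridin-2-yl differ at all in this assay.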